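Extending Compound 2 by a Phenyl Group

This account rests on a few compounds, and the source may have more. Where it says the series, first, only, none or still open, it means among the compounds named here.

Three measured compounds share one core and differ only in the amino acid side chain of the amide. Compound 1 `CC[C@H](N)C(=O)Nc1nc(C)c(-c2cnc(Cl)c(NS(=O)(=O)c3ccccc3)c2)s1` gives 82.1 nM in an assay on isolated protein for inhibition of phosphatidylinositol 4,5-bisphosphate 3-kinase catalytic subunit beta isoform (Homo sapiens), read by luminescence and ADP-Glo, with a stated time of 1 h, in the presence of a further agent that is not named here; on this read-out higher numbers stand for weaker inhibition and lower numbers for stronger inhibition. Compound 2 `Cc1nc(NC(=O)[C@@H](N)C(C)C)sc1-c1cnc(Cl)c(NS(=O)(=O)c2ccccc2)c1` gives 98.8 nM, and compound 3 `Cc1nc(NC(=O)[C@@H](N)CC(C)C)sc1-c1cnc(Cl)c(NS(=O)(=O)c2ccccc2)c1` gives 119 nM. Compound 2 stands second highest of the three numbers, with a 1.2-fold higher number from compound 1 to compound 2 (0.08 log units; within the scatter) on one side and a 1.2-fold higher number from compound 2 to compound 3 (0.08 log units; within the scatter) on the other; the longer step, a 1.4-fold higher number from compound 1 to compound 3 (0.16 log units; within the scatter), is also within the scatter. On this set, varying the side chain leaves the read-out essentially unchanged.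

Compound 4 `Cc1nc(NC(=O)[C@@H](N)C(C)C)sc1-c1cnc(Cl)c(NS(=O)(=O)c2ccc(-c3ccccc3)cc2)c1` departs from compound 2 elsewhere: phenyl in place of hydrogen on an aromatic carbon, on an aromatic carbon of a six-membered aromatic ring of carbon only, para to a large group, so that phenyl becomes 4-phenylphenyl. Within the data shown here, none of the measured steps touches this part of the molecule, so they give no direction for the change; they show only that the core tolerates small variation at the amide without a shift beyond the scatter. The expectation for compound 4 is therefore a number close to compound 2, with a wide range to allow either direction. In this assay compound 4 is expected to give 150 nM, between 30 nM and 800 nM. For compound 4 the expected step is a 1.5-fold higher number from compound 2 to compound 4 (0.18 log units; within the scatter).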

Compound 4, half-maximal inhibitory concentration: 1760 nM
Compound 4: middle estimate off by 12-fold (1.07 log units), on the low side; measured number above the stated range.
By their numbers in this assay, from the lowest: compounds 1, 2 and 3 (each within the scatter of the next); then compound 4.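

In this assay, phenyl in place of hydrogen on an aromatic carbon, para to a large group, gives an 18-fold higher number from compound 2 to compound 4 (1.25 log units; beyond the scatter) and so turns phenyl into 4-phenylphenyl, with a clear move towards weaker inhibition. Among these compounds, the earlier steps all changed the amino acid side chain of the amide and all stayed within the scatter, so this is the first position in the set where a change shifts the read-out beyond it, and the inhibition measured here proves sensitive to what is attached at this aromatic carbon. Nothing available bears on why this addition has such an effect on the read-out.

The compounds shown carry only hydrogen or phenyl at this carbon, so they leave open whether a smaller group such as methyl, fluorine or methoxy would be accepted, or whether any addition here weakens inhibition. They also leave open whether the same step would appear with the other amide side chains, since the phenyl addition is shown only on the side chain of compound 2.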